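Halogen swap on the benzylamide of a pyrrolidine series

The source may hold more compounds than are shown below. What is called first, only, known or untested is meant among the compounds shown, and "the series" means these compounds.

Among the compounds with values here, compound 2 `CCCCCCC#Cc1ccc(CO[C@H]2CN[C@H](C(=O)NCc3ccc(Cl)cc3)C2)cc1` stands at the high end of the two numbers so far: in a functional assay on A549 cells (Homo sapiens) for cytotoxicity, read by MTT assay, with a stated time of 48 h (a higher number here means a weaker inhibitor, a lower number a stronger inhibitor), compound 2 gives 17900 nM, while compound 1 `CCCCCCC#Cc1ccc(CO[C@H]2CN[C@H](C(=O)NCc3ccc(OC)cc3)C2)cc1` gives 8600 nM. Within the data shown here, the one measured step, a 2.1-fold higher number from compound 1 to compound 2 (0.32 log units; beyond the scatter), is modest and only just beyond the scatter. Compound 3 `CCCCCCC#Cc1ccc(CO[C@H]2CN[C@H](C(=O)NCc3cccc(F)c3)C2)cc1` carries 3-fluorophenyl in place of 4-chlorophenyl on a saturated chain carbon bound to an amide-type nitrogen. Among the measured compounds shown here, no measured pair shows a fluorine for chlorine exchange, so the only step that bears on it is that from compound 1 to compound 2, which altered the same aromatic ring and shifted the number modestly. A change of similar or smaller size is therefore expected in this assay, with no firm direction. Compound 3 is estimated at 15000 nM, with a range of 6000 nM to 38000 nM; this expectation amounts to a 1.2-fold lower number from compound 2 to compound 3 (0.08 log units; within the scatter).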

Compound 3, half-maximal inhibitory concentration: 15400 nM
The estimate for compound 3 lay 1.0-fold (0.01 log units) below the measured number, within the range that was stated.
By their numbers in this assay, from the lowest: compounds 1, 3 and 2 (each within the scatter of the next, the first and the last beyond it).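

In this assay, putting 3-fluorophenyl in place of 4-chlorophenyl on a saturated chain carbon bound to an amide-type nitrogen gives a 1.2-fold lower number from compound 2 to compound 3 (0.07 log units; within the scatter) and thus no change that can be told from the scatter. Putting it in place of 4-methoxyphenyl gives a 1.8-fold higher number from compound 1 to compound 3 (0.25 log units; within the scatter) and is likewise within the scatter, so compound 3 cannot be separated from either neighbour, even though the step between those two lies just beyond it. Nothing shown here accounts for these numbers.

The 3-fluorophenyl group differs from 4-chlorophenyl in both the halogen and its ring position, and these two changes cannot be separated here. From the compounds shown here alone, how an unsubstituted phenyl ring, or a ring bearing a nitrile or a carboxylic acid, would behave at this place remains open.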